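From Chloro to Methyl on the Anilide Ring

This account rests on a few compounds, and the source may have more. Where it says the series, first, only, none or still open, it means among the compounds named here.

Three amides built on the core of compound 1 `O=C(Nc1ccc(F)cc1)c1cc(Cl)ccc1O` have been tested in a physicochemical assay for solubility; on this read-out lower numbers stand for lower solubility and higher numbers for higher solubility. In this assay compound 1 gives 1.6 ug/mL. Compound 2 `O=C(Nc1ccc(C(F)(F)F)cc1)c1cc(Cl)ccc1O` returns only the limit < 1 ug/mL in this assay. Compound 3 `O=C(Nc1ccc(Cl)cc1)c1cc(Cl)ccc1O` likewise returns only the limit < 1 ug/mL in this assay, so no number is known for compound 3, and (the limit of < 1 ug/mL in this assay, at which 2 of the 3 values shown sit). The measured steps are an at least 1.6-fold lower number from compound 1 to compound 2 (0.20 log units; that floor lies within the scatter) and an at least 1.6-fold lower number from compound 1 to compound 3 (0.20 log units; that floor lies within the scatter), while a step that the two limits leave unreadable from compound 2 to compound 3. Compound 4 `Cc1ccc(NC(=O)c2cc(Cl)ccc2O)cc1` differs from compound 3 by methyl in place of chloro on an aromatic carbon. Going by the values given here, no measured step involves methyl, and the only step that reaches compound 3, an at least 1.6-fold lower number from compound 1 to compound 3 (0.20 log units; that floor lies within the scatter), has a floor that lies within the scatter, so the data give little guide beyond a small upward move at most. Compound 4 is expected to give about 1.5 ug/mL in this assay, within 0.5 ug/mL to 4.5 ug/mL. For compound 4 this means an expected step of an at least 1.5-fold higher number from compound 3 to compound 4 (0.17 log units; that floor lies within the scatter), with a fair chance that only the limit is reported again.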

Compound 4, solubility: < 1 ug/mL
Compound 4 gave a limit, no number; the forecaster's own chance of this, stated with the estimate: 40%; middle value at least 1.5-fold (0.17 log units) away from the limit.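

Methyl, on the aromatic carbon para to a large group, is the third replacement for fluoro that yields a limit rather than a number in this assay, after trifluoromethyl in compound 2 and chloro in compound 3. Going by these compounds alone, the one step that can be read is an at least 1.6-fold lower number from compound 1 to compound 4 (0.20 log units; that floor lies within the scatter), so nothing here shows a change beyond the scatter for methyl in place of fluoro, though the true size of the step remains unknown; the steps from compound 2 and compound 3 to compound 4 cannot be read. At this position the read-out now gives little to separate the groups: the limit of < 1 ug/mL in this assay, at which 3 of the 4 values shown sit.

As far as these compounds go, the order among trifluoromethyl, chloro and methyl remains open. So does whether an amine or a carboxylic acid at this position would give a number rather than a limit.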